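Thiophen-2-yl sulfonamide on the shared benzoxazole-aniline core

The compounds below may be only part of what the source reports. "The series", "measured", "known", "first", "only" and "open" are said of these compounds alone.

Compound 3 `O=S(=O)(Nc1ccc(-c2nc3ccccc3o2)cc1)c1ccccc1F` has no exact number in an assay on isolated protein for inhibition of malate dehydrogenase, mitochondrial (Sus scrofa), with stated times of 45 min and 30 min; a lower number here means a stronger inhibitor, a higher number a weaker inhibitor: in this assay compound 3 gives > 63000 nM, which is a limit of the assay. Compound 1 `O=S(=O)(Nc1ccc(-c2nc3ccccc3o2)cc1)c1ccc(Cl)s1` is in the same position, since compound 1 gives > 63000 nM, again a limit. Compound 2 `O=S(=O)(Nc1ccc(-c2nc3ccccc3o2)cc1)c1cccc(O)c1` likewise gives > 63000 nM, a limit. All three sit at the limit of > 63000 nM in this assay, at which 3 of the 3 values shown sit, so the steps a step that the two limits leave unreadable from compound 1 to compound 3 and a step that the two limits leave unreadable from compound 2 to compound 3 cannot be read. Compound 4 `O=S(=O)(Nc1ccc(-c2nc3ccccc3o2)cc1)c1cccs1` differs from compound 3 by thiophen-2-yl in place of 2-fluorophenyl on a sulfonyl sulfur. With every neighbour at the limit, no readable step is expected. Compound 4 is therefore estimated at 90000 nM, between 30000 nM and 300000 nM. The step this estimate implies from compound 3 to compound 4 is expected to be a step that the limit leaves unreadable from compound 3 to compound 4.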

Compound 4, half-maximal inhibitory concentration: > 63000 nM
Compound 4 was reported as a limit (the forecaster's own chance of this, stated with the estimate: 85%); the middle value does not contradict the limit.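

For the compounds shown here, compound 4 is also reported only as a limit in this assay, so no step from compound 1, compound 2 or compound 3 to compound 4 can be read: the limit of > 63000 nM in this assay, at which 4 of the 4 values shown sit. The compounds shown leave open whether any group on the sulfonyl sulfur of the shared core gives measurable inhibition, and how these four compounds rank.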